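The source may report more compounds than this note shows. Statements on the series, on what has been measured and on what is new or still open speak of the compounds shown alone.

Compound 1 `COc1cc(-c2cc(-c3ccc(Cl)cc3)nc(-c3ccccc3)n2)cc(OC)c1OC`: > 25000 nM (a limit)
Compound 2 `COc1cc(-c2cc(-c3ccc(Br)cc3)nc(-c3ccccc3)n2)cc(OC)c1OC`: > 25000 nM (a limit)
Compound 3 `COc1cc(-c2cc(-c3ccc(C)cc3)nc(-c3ccccc3)n2)cc(OC)c1OC`: 5110 nM

Going by the values given here, in a functional assay on MDA-MB-231 cells (Homo sapiens) for inhibition, read by MTT assay, with a stated time of 48 h (a lower number here means a stronger inhibitor, a higher number a weaker inhibitor), compound 3 gives 5110 nM, the only true number of the three. Compound 1 and compound 2 reach only (the limit of > 25000 nM in this assay, at which 2 of the 3 values shown sit). Compound 4 `COc1ccc(-c2cc(-c3cc(OC)c(OC)c(OC)c3)nc(-c3ccccc3)n2)c(OC)c1` carries a larger change on the same ring: 2,4-dimethoxyphenyl in place of 4-methylphenyl on an aromatic carbon. Among the compounds with values here, two measured steps bear on this ring, an at least 4.8-fold lower number from compound 1 to compound 3 (0.68 log units; beyond the scatter) and an at least 4.8-fold lower number from compound 2 to compound 3 (0.68 log units; beyond the scatter). They show that its substituent can move the result, and that the halogens give the weaker results. Neither tests methoxy groups, so only a small rise in the number is expected, possibly within the scatter. That is an expected 1.8-fold higher number from compound 3 to compound 4 (0.25 log units; within the scatter). For compound 4 the estimated value is 9000 nM, with an expected range of 3000 nM to 25000 nM.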

Compound 4, half-maximal inhibitory concentration: 1440 nM
Compound 4: the middle estimate sits 6.3-fold (0.80 log units) above what was measured, and the stated range ends above it.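

In this assay this position accepts the larger 2,4-dimethoxyphenyl group, and the number drops below that seen with 4-methylphenyl (a 3.5-fold lower number from compound 3 to compound 4 (0.55 log units; beyond the scatter)). The drop is larger still against the rings carrying a halogen (an at least 17-fold lower number from compound 2 to compound 4 (1.23 log units; beyond the scatter); an at least 17-fold lower number from compound 1 to compound 4 (1.23 log units; beyond the scatter)), so methoxy groups, untested until now, give the best result on this ring among these compounds. Those two steps are minimum sizes only, since compound 1 and compound 2 stand at a limit: the limit of > 25000 nM in this assay, at which 2 of the 4 values shown sit.

From the compounds shown here alone, whether a single methoxy group would do as well as the pair remains open. So does how an amine or a carboxylic acid on this ring would behave.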